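The source may report more compounds than this note shows. Statements on the series, on what has been measured and on what is new or still open speak of the compounds shown alone.

Compounds measured so far:
compound 1 `Cc1ccc(-c2cs/c(=N/NC(=O)CSc3nnnn3-c3ccccc3)n2-c2ccccc2)cc1`: > 500 ug/mL
compound 2 `O=C(CSc1ncccn1)N/N=c1/scc(-c2ccccc2)n1-c1ccccc1`: 107 ug/mL
compound 3 `O=C(CSc1ncccn1)N/N=c1/scc(-c2ccc(Br)cc2)n1-c1ccccc1`: 273 ug/mL

Three compounds sharing one core have been run in an ADME assay on NIH3T3 cells (Mus musculus) for cytotoxicity, read by MTT assay, with a stated time of 24 h; on this read-out higher numbers stand for weaker inhibition and lower numbers for stronger inhibition. Compound 1 `Cc1ccc(-c2cs/c(=N/NC(=O)CSc3nnnn3-c3ccccc3)n2-c2ccccc2)cc1` gives only a limit of the assay, > 500 ug/mL, and not a number. Among the measured compounds shown here, compound 2 `O=C(CSc1ncccn1)N/N=c1/scc(-c2ccccc2)n1-c1ccccc1` gives 107 ug/mL, and compound 3 `O=C(CSc1ncccn1)N/N=c1/scc(-c2ccc(Br)cc2)n1-c1ccccc1` gives 273 ug/mL, the highest of the two numbers; the only measured step is a 2.6-fold higher number from compound 2 to compound 3 (0.41 log units; beyond the scatter).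

The next compound, compound 4 `Cc1ccc(-c2cs/c(=N/NC(=O)CSc3ncccn3)n2-c2ccccc2)cc1`, differs from compound 3 by methyl in place of bromo on an aromatic carbon. For the measured compounds named here, no measured step covers a methyl in place of bromo; the only one that touches the same aromatic carbon is a 2.6-fold higher number from compound 2 to compound 3 (0.41 log units; beyond the scatter), which shows that a change there can move the number beyond the scatter. Compound 1, which carries the same methyl group on a different thioether, stands at a limit, so little can be drawn from it. On this basis the step in this assay is expected to be small, a 1.1-fold lower number from compound 3 to compound 4 (0.04 log units; within the scatter), with either direction possible. Compound 4 is therefore estimated at 250 ug/mL, within 100 ug/mL to 600 ug/mL.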

Compound 4, half-maximal inhibitory concentration: > 500 ug/mL
Compound 4 gave a limit, no number (the forecaster's own chance of this, stated with the estimate: 25%); at least 2.0-fold (0.30 log units) between middle value and limit.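

With methyl in place of hydrogen at this position of the 4-methylphenyl ring, this assay shows an at least 4.6-fold higher number from compound 2 to compound 4 (0.66 log units; beyond the scatter), so bromo and methyl both leave the number higher than hydrogen does, and the methyl step is the larger of the two on its floor alone. The swap of bromo for methyl reads as an at least 1.8-fold higher number from compound 3 to compound 4 (0.26 log units; that floor lies within the scatter); compound 4 stands at a limit, so this is only a floor, and the real size of the difference between these two groups stays unresolved. The step between compound 1 and compound 4 cannot be read, as both stand at a limit: the limit of > 500 ug/mL in this assay, at which 2 of the 4 values shown sit.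

The compounds shown leave open how a methoxy group, an amine or a carboxylic acid at this position would read. They also leave open what pyrimidin-2-yl and 1-phenyl-1H-tetrazol-5-yl on the sulfur each contribute.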